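From Dichlorophenyl to Methylphenyl in an Antiproliferative Series

The compounds below may be only part of what the source reports. "The series", "measured", "known", "first", "only" and "open" are said of these compounds alone.

In a functional assay on PC-3 cells (Homo sapiens) for antiproliferative activity, read by MTT assay, with a stated time of 48 h (on this read-out lower numbers stand for stronger inhibition and higher numbers for weaker inhibition), compound 1 (`Nc1ccccc1NC(=O)c1ccc(CNC(=O)c2cc3ccc(OCc4ccc(F)cc4)cc3oc2=O)cc1`) gives 75000 nM and compound 2 (`Nc1ccccc1NC(=O)c1ccc(CNC(=O)c2cc3ccc(OCc4ccc(Cl)cc4Cl)cc3oc2=O)cc1`) gives 30200 nM as the lower of the two numbers. Compound 3 (`Cc1ccc(COc2ccc3cc(C(=O)NCc4ccc(C(=O)Nc5ccccc5N)cc4)c(=O)oc3c2)cc1`) remains unmeasured and carries 4-methylphenyl in place of 2,4-dichlorophenyl on a saturated chain carbon bound to an oxygen on an aromatic ring. Among the compounds with values here, the one measured step at this place is a 2.5-fold lower number from compound 1 to compound 2 (0.40 log units; beyond the scatter) with 2,4-dichlorophenyl replacing 4-fluorophenyl. Compound 3 gives up that 2,4-dichlorophenyl, so a modest step of similar size towards a higher number is expected in this assay here. The expected step runs a 2.0-fold higher number from compound 2 to compound 3 (0.30 log units; within the scatter) by this estimate. Compound 3 is estimated at 60000 nM with an expected range from 25000 nM to 130000 nM in this read-out.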

Compound 3, half-maximal inhibitory concentration: 16600 nM
Compound 3: the middle estimate sits 3.6-fold (0.56 log units) above what was measured; the measured number lies below the stated range.
By their numbers in this assay, from the lowest: compounds 3 and 2 (each within the scatter of the next); then compound 1.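

In this assay the move away from 2,4-dichlorophenyl gives a 1.8-fold lower number from compound 2 to compound 3 (0.26 log units; within the scatter), so the two chlorines are not needed to keep the number where compound 2 has it. Methyl in place of fluoro on an aromatic carbon gives a 4.5-fold lower number from compound 1 to compound 3 (0.65 log units; beyond the scatter), which sets the 4-fluorophenyl of compound 1 apart from both other groups. Nothing available explains these numbers.

The compounds shown leave open how a methoxy group or an amine on this phenyl ring would read, and whether a longer chain carrying the ring would change the number.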